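Swapping a Benzyl Arm for a Trimethylphenyl Ring

The source may report more compounds than this note shows. Statements on the series, on what has been measured and on what is new or still open speak of the compounds shown alone.

compound 1, `Cc1ccccc1Nc1nc(Nc2ccccc2)ncc1Cl`: > 100000 nM
compound 2, `CCN1CCN(c2ccc(Nc3ncc(Cl)c(Nc4ccccc4C)n3)cc2)CC1`: 2060 nM
compound 3, `Cc1ccc(CNc2nc(Nc3ccc(N4CCN(C)CC4)cn3)ncc2Cl)cc1`: 12700 nM

Of the compounds shown here, three have been measured in a functional assay on Jurkat cells (Homo sapiens) for inhibition, read by CCK-8 assay, with a stated time of 48 h; a higher number here means a weaker inhibitor of growth, a lower number a stronger inhibitor of growth. For compound 1 the result is only a limit, > 100000 nM, at the edge of what the assay reports (the limit of > 100000 nM in this assay, at which 1 of the 3 values shown sits). Compound 2 gives 2060 nM and compound 3 gives 12700 nM, so compound 3 stands as the higher of the two real numbers, sitting well above compound 2. For the measured compounds named here, the single measured step, an at least 48-fold lower number from compound 1 to compound 2 (1.68 log units; beyond the scatter), concerns a change on an aromatic carbon elsewhere in the shared core and so does not speak to the change studied here.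

Compound 4, `Cc1cc(C)c(Nc2nc(Nc3ccc(N4CCN(C)CC4)cn3)ncc2Cl)c(C)c1`, is compound 3 with 2,4,6-trimethylphenyl in place of 4-methylbenzyl on a nitrogen on an aromatic ring. Going by the values given here, no measured step bears on this exchange, so the expectation rests on the spread seen across compounds 2 and 3 alone. The step from compound 3 to compound 4 is estimated as a 2.5-fold lower number from compound 3 to compound 4 (0.40 log units; beyond the scatter), a modest move toward stronger growth inhibition, though the data give little to anchor its size. Compound 4 is therefore expected to give about 5000 nM in this assay, within a range from 1500 nM to 20000 nM.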

Compound 4, concentration for 50% growth inhibition: 7600 nM
Compound 4: the middle estimate sits 1.5-fold (0.18 log units) below what was measured; measured number inside the range.
By their numbers in this assay, from the lowest: compound 2; then compounds 4 and 3 (each within the scatter of the next). At a limit, above all of these: compound 1.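

For the compounds shown here, the exchange of 4-methylbenzyl for 2,4,6-trimethylphenyl on a nitrogen on an aromatic ring gives the first measured step at this place in this assay: a 1.7-fold lower number from compound 3 to compound 4 (0.22 log units; within the scatter). The earlier compounds shown here offered no reading here, and this one shows that the two arms cannot be told apart in this assay, even though the entering group has one more carbon and the same difference, cut one bond further out, replaces (4-methylbenzyl)amino with (2,4,6-trimethylphenyl)amino. The compounds shown hold nothing that accounts for this outcome, so it stands as an observation without an explanation.

From the compounds shown here alone, what remains open is whether this place responds to any change at all, since both arms here are carbon-only aromatic groups with no hydrogen-bond donors or acceptors, and a single step within the scatter cannot settle that. An amine or a carboxylic acid on the arm, or a longer chain in its place, could show whether growth inhibition in this assay can be moved from this nitrogen.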